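Notes on the step from compound 3 to compound 4

The source may report more compounds than this note shows. Statements on the series, on what has been measured and on what is new or still open speak of the compounds shown alone.

The series is read in a functional assay on BGC-823 cells (Homo sapiens) for cytotoxicity, read by CCK-8 assay, with a stated time of 24 h; on this read-out higher numbers stand for weaker inhibition and lower numbers for stronger inhibition. Compound 1 `C/C(=C\c1cc(-c2ccccc2)co1)C(N)=O` carries an unsubstituted phenyl on the shared core; in this assay compound 1 returns > 50000 nM, which is a limit of the assay and not a number. Compound 2 `C/C(=C\c1cc(-c2ccc(C)nc2)co1)C(N)=O` replaces that phenyl with a methyl-bearing pyridyl; in this assay compound 2 likewise returns > 50000 nM, again a limit rather than a number. Compound 3 `C/C(=C\c1ccc(-c2ccc(C)cc2)o1)C(N)=O` places a methyl-bearing phenyl on a differently connected furan; in this assay compound 3 returns > 50000 nM, also a limit and not a number. Taken together the three values rest on (the limit of > 50000 nM in this assay, at which 3 of the 3 values shown sit), so no measured step within the series can be stated, and compound 3 stands exactly where the other two stand: at the limit, without a number.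

Compound 4 `C/C(=C\c1ccc(-c2ccc(F)cc2)o1)C(N)=O` differs from compound 3 by fluoro in place of methyl on an aromatic carbon. Within the data shown here, no step between measured compounds is available for this change. Given (the limit of > 50000 nM in this assay, at which 3 of the 3 values shown sit), the step from compound 3 to compound 4 is expected to be none beyond the scatter a step that the limit leaves unreadable from compound 3 to compound 4. Compound 4 is therefore estimated at 70000 nM, with a range from 25000 nM to 250000 nM, and most probably this assay will again report only a limit for compound 4.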

Compound 4, half-maximal inhibitory concentration: 940 nM
For compound 4 the middle estimate is 74-fold (1.87 log units) above the measured one; measured number outside the range, below it.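

In this assay, fluoro in place of methyl on an aromatic carbon, para to a large group, gives an at least 53-fold lower number from compound 3 to compound 4 (1.72 log units; beyond the scatter), so a change of one heavy atom at this position is enough to take the series off the limit. Compound 3 gives > 50000 nM, which is a limit and not a number, so the step is known only as a minimum and its full size cannot be read. Compound 4 therefore provides the only numerical value in the series, and this position emerges as one that can separate a readable value from a limit: the limit of > 50000 nM in this assay, at which 3 of the 4 values shown sit.

From the compounds shown here alone, it remains open whether the change depends on the presence of fluoro or on the loss of methyl, and whether hydrogen, chloro, methoxy or an amine at this position would also give a numerical value. Going by these compounds, it is equally open whether fluoro in the same place on the phenyl of compound 1, with its differently connected core, would have any comparable effect.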